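Replacing a Fluorophenyl with a Vinylphenyl on a Cytotoxic Scaffold

The compounds below may be only part of what the source reports. "The series", "measured", "known", "first", "only" and "open" are said of these compounds alone.

For the measured compounds named here, compound 1 `COC1=C(C)C(=O)/C(=C(O)/C=C/c2ccc(F)cc2)C(=O)C1(C)C` gives 2.7 ug/mL in a functional assay on KB cells (Homo sapiens) for cytotoxicity (a lower number here means that less compound is needed, a higher number that more compound is needed for the effect), the higher of the two numbers measured so far, while compound 2 `COC1=C(C)C(=O)/C(=C(O)/C=C/c2c(C)cc(C)cc2C)C(=O)C1(C)C` gives 1.84 ug/mL, a gap that lies within the scatter. Compound 3 `C=Cc1ccccc1/C=C/C(O)=C1/C(=O)C(C)=C(OC)C(C)(C)C1=O` differs from compound 1 in one place: 2-vinylphenyl in place of 4-fluorophenyl on a double-bonded chain carbon bound to a double-bonded chain carbon. Going by the values given here, no measured pair carries this change, so no step beyond the scatter is expected in either direction, because compound 2 gives 1.84 ug/mL and stays within the scatter of compound 1. Compound 3 is therefore expected to give about 2.3 ug/mL, in a range from 1 ug/mL to 5.5 ug/mL, an expected step of a 1.2-fold lower number from compound 1 to compound 3 (0.07 log units; within the scatter).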

Compound 3, concentration for half-maximal effect: 1.1 ug/mL
Beside the measured number, compound 3's estimate is 2.1-fold (0.32 log units) above it; measured number inside the range.
By their numbers in this assay, from the lowest: compounds 3, 2 and 1 (each within the scatter of the next, the first and the last beyond it).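

In this assay, the group on this double-bonded chain carbon can move the number beyond the scatter: 2-vinylphenyl in place of 4-fluorophenyl gives a 2.5-fold lower number from compound 1 to compound 3 (0.39 log units; beyond the scatter). For the compounds shown here, this is the first step at this position that can be read, and it shows that the fluorine is not required for the lower number. Nothing measured here explains the step.

Whether the vinyl group alone accounts for the step remains open, since the fluorine leaves in the same change. Also open, as far as these compounds go, is what a plain phenyl, a 2-ethylphenyl or an aminophenyl would give at this position.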